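The source may report more compounds than this note shows. Statements on the series, on what has been measured and on what is new or still open speak of the compounds shown alone.

Measured so far in a functional assay (Pituitary gland cell) with Rattus norvegicus as the target; a higher number here means that more compound is needed for the effect, a lower number that less compound is needed:
compound 1 `CNC(=O)NCc1ccccc1-c1ccc(CN2C(=O)[C@H](NC(=O)CC(C)(C)N)CCc3ccccc32)cc1`, 6 nM
compound 2 `CC(C)(N)C(=O)N[C@@H]1CCc2ccccc2N(Cc2ccc(-c3ccccc3CNC(=O)NCCO)cc2)C1=O`, 2 nM
compound 3 `CC(C)(N)C(=O)N[C@@H]1CCc2ccccc2N(Cc2ccc(-c3ccccc3CNC(=O)NCc3ccccc3)cc2)C1=O`, 390 nM

Compound 2 gives the lowest number of the three in this assay. Compound 1 sits nearest, a step beyond the scatter; compound 3 is furthest off, with the step of a 200-fold higher number from compound 2 to compound 3 (2.29 log units; beyond the scatter). Compound 1 and compound 2 differ in more than one place, so their two values are only noted side by side.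

Compound 4 `CC(C)(N)C(=O)N[C@@H]1CCc2ccccc2N(Cc2ccc(-c3ccccc3-c3nn[nH]n3)cc2)C1=O` is not yet measured. It differs from compound 2 at the terminus of the biaryl: 2H-tetrazol-5-yl in place of (((2-hydroxyethyl)carbamoyl)amino)methyl on an aromatic carbon. Within the data shown here, the one step that bears on this position is a 200-fold higher number from compound 2 to compound 3 (2.29 log units; beyond the scatter), where a larger group on the saturated chain carbon cost a great deal. The change to compound 4 goes the other way in size, removing the whole eight-atom chain and putting a compact five-membered aromatic ring directly on the aromatic carbon, so that step is only a loose guide. Among the measured compounds shown here, no measured pair shows this exact exchange, and what is kept of the hydrogen-bonding pattern is uncertain.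

Compound 4 is therefore expected to lose some ground, with an estimated 20 nM, range 3 nM to 150 nM, corresponding to an expected step of a 10-fold higher number from compound 2 to compound 4 (1.00 log units; beyond the scatter).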

Compound 4, concentration for half-maximal effect: 30 nM
Beside the measured number, compound 4's estimate is 1.5-fold (0.18 log units) below it, and the stated range covers the measured number.
By their numbers in this assay, from the lowest: compound 2; then compound 1; then compound 4; then compound 3.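

In this assay, the aromatic carbon ortho to a large group accepts a compact ring in place of the whole chain: putting 2H-tetrazol-5-yl there instead of (((2-hydroxyethyl)carbamoyl)amino)methyl gives a 15-fold higher number from compound 2 to compound 4 (1.18 log units; beyond the scatter) and so costs a large step, but less than the benzyl change did. Measured against the ((benzylcarbamoyl)amino)methyl terminus, the same ring gives a 13-fold lower number from compound 3 to compound 4 (1.11 log units; beyond the scatter) and so counts as a large gain, which means its standing depends on which chain it replaces: worse than the hydroxyethyl chain of compound 2 and better than the benzyl chain of compound 3. Nothing available accounts for either step.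

The compounds shown leave open how a carboxylic acid or an amine on the same aromatic carbon would compare with 2H-tetrazol-5-yl, and whether a longer chain ending in hydroxyl would hold the value of compound 2 2 nM in this assay. They also leave open whether 2H-tetrazol-5-yl would give a similar step on the core of compound 1, whose other side chain differs.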